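The source may report more compounds than this note shows. Statements on the series, on what has been measured and on what is new or still open speak of the compounds shown alone.

Working notes on a small set of amidrazone thiosemicarbazides read in a functional assay on A-375 cells (Homo sapiens) for cytotoxicity, read by MTT assay, with a stated time of 72 h, tested at 100 uM; a lower number here means less inhibition of growth, a higher number more inhibition of growth at the concentration tested.

Compound 3 `N/C(=N\NC(=S)N1CCSCC1)c1ccccn1` gives 87.8%. Compound 1 `N/C(=N\NC(=S)N1CCOCC1)c1ccccn1` shares the same core but carries morpholin-4-yl in place of thiomorpholin-4-yl on a thiocarbonyl carbon; in this assay compound 1 gives 14%. The resulting step of a number 73.8 percentage points lower from compound 3 to compound 1 (beyond the scatter) is the largest movement in the set. Compound 2 `Cc1cccc(/C(N)=N/NC(=S)N2CCSCC2)n1` differs from compound 3 only by methyl in place of hydrogen on an aromatic carbon; in this assay compound 2 gives 77.4%, and the step of a number 10.4 percentage points higher from compound 2 to compound 3 (beyond the scatter) is modest though beyond the scatter. The values of compound 1 and compound 2 are not broken down as a step here; they simply stand far apart.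

Compound 4 `Cc1cccc(/C(N)=N/NC(=S)N2CCOCC2)n1` is not yet measured. It relates to compound 2 by morpholin-4-yl in place of thiomorpholin-4-yl on a thiocarbonyl carbon, and the place of the change is worded identically to that of the measured pair, so this is the same change applied to a core that differs only by methyl in place of hydrogen on an aromatic carbon. Within the data shown here, the expected step of a number 65.4 percentage points lower from compound 2 to compound 4 (beyond the scatter) is set beside the measured step of a number 73.8 percentage points lower from compound 3 to compound 1 (beyond the scatter) and rests on it, because a number 73.8 percentage points lower from compound 3 to compound 1 (beyond the scatter) is the only instance of this change in the set. The one difference in the cores moved the number only modestly, so no large correction is applied. Compound 4 is expected to give 12%, with a plausible range from 2% to 35%.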

Compound 4, percent growth inhibition at one concentration: 83.8%
Compound 4: the middle estimate sits 71.8 percentage points below what was measured; measured number outside the range, above it.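

In this assay, morpholin-4-yl in place of thiomorpholin-4-yl on a thiocarbonyl carbon gives a number 6.4 percentage points higher from compound 2 to compound 4 (within the scatter), so the large drop seen on the core of compound 3 does not carry over to the core of compound 2: the same change on two cores in this assay, a number 73.8 percentage points lower (beyond the scatter) from compound 3 to compound 1 and a number 6.4 percentage points higher (within the scatter) from compound 2 to compound 4, 80.2 percentage points apart, beyond the scatter of two such steps. Read along the other edge of the set, methyl in place of hydrogen on an aromatic carbon gives a number 69.8 percentage points higher from compound 1 to compound 4 (beyond the scatter), so the size of that step also depends on which ring sits on the thiocarbonyl carbon: the same change on two cores in this assay, a number 10.4 percentage points higher (beyond the scatter) from compound 2 to compound 3 and a number 69.8 percentage points lower (beyond the scatter) from compound 4 to compound 1, 80.2 percentage points apart, beyond the scatter of two such steps. Among these compounds, the two changes therefore do not act independently, with compound 1 at 14% the only low value of the four, but a single pair on each core shows neither why they interact nor whether either core's behaviour is the more typical one.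

Still open, from the compounds shown here alone, is whether the low value of compound 1 is specific to the pairing of morpholin-4-yl with that core or would recur with other groups on the same core. Also open, going by these compounds, is how a piperidin-1-yl or piperazin-1-yl group on the thiocarbonyl carbon, or an ethyl or methoxy group in place of the methyl on the aromatic carbon, would read in this assay.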